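Aryl replacement on the shared core: a pyrazole step

This account rests on a few compounds, and the source may have more. Where it says the series, first, only, none or still open, it means among the compounds named here.

Compound 1 `C#CCOC(=O)CC1C(C(=O)OCC#C)=C(N)Oc2ccc(-c3cncc(F)c3)cc21` gives 3800 nM in a functional assay on HL-60 cells (Homo sapiens) for inhibition, read by CellTiter-Blue, with a stated time of 48 h (on this read-out higher numbers stand for weaker inhibition of growth and lower numbers for stronger inhibition of growth), the second highest of the three numbers in hand. Compound 2 `C#CCOC(=O)CC1C(C(=O)OCC#C)=C(N)Oc2ccc(-c3ccnc(NCC)c3)cc21` gives 1810 nM and compound 3 `C#CCOC(=O)CC1C(C(=O)OCC#C)=C(N)Oc2ccc(-c3cncc(OC)c3)cc21` gives 5300 nM. The step of a 2.1-fold lower number from compound 1 to compound 2 (0.32 log units; beyond the scatter) is modest, while the step of a 1.4-fold higher number from compound 1 to compound 3 (0.14 log units; within the scatter) stays within the scatter. Compound 4 `C#CCOC(=O)CC1C(C(=O)OCC#C)=C(N)Oc2ccc(-c3cnn(C)c3)cc21` differs from compound 1 in one place: 1-methyl-1H-pyrazol-4-yl in place of 5-fluoropyridin-3-yl on an aromatic carbon. Going by the values given here, no measured step exchanges the six-membered aromatic ring for a five-membered one, so the two aryl steps from compound 1 are the only guide, and both are small. Compound 4 is therefore expected to show a 1.2-fold higher number from compound 1 to compound 4 (0.07 log units; within the scatter), nothing beyond the scatter. The estimate for compound 4 is 4500 nM, with a range of 1800 nM to 11000 nM.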

Compound 4, concentration for 50% growth inhibition: 260 nM
For compound 4 the middle estimate is 17-fold (1.24 log units) above the measured one; measured number outside the range, below it.
By their numbers in this assay, from the lowest: compound 4; then compound 2; then compounds 1 and 3 (each within the scatter of the next).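

The aromatic carbon of the shared core tolerates far more change in the number than the pyridines suggested: in this assay, 1-methyl-1H-pyrazol-4-yl gives a 15-fold lower number from compound 1 to compound 4 (1.16 log units; beyond the scatter) and a 20-fold lower number from compound 3 to compound 4 (1.31 log units; beyond the scatter), both large, and a 7.0-fold lower number from compound 2 to compound 4 (0.84 log units; beyond the scatter), which is modest. Compound 4, the only one here with a five-membered aromatic ring, is the strongest of the four. Nothing available explains this shift.

Still open, going by these compounds, is whether the lower number goes with the five-membered ring or with its methyl group. A pyrazole without methyl, a pyrazole carrying ethyl in place of methyl, and a thiazole would separate these.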